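Aryl swap on the amide nitrogen of a fused core

The source may report more compounds than this note shows. Statements on the series, on what has been measured and on what is new or still open speak of the compounds shown alone.

Compound 1 `CO[C@@H]1CC=C2NN(c3ccc([N+](=O)[O-])cc3)C(=O)CC[C@]2(c2ccccc2)O1`: 8700 nM
Compound 2 `CO[C@@H]1CC=C2N(c3ccc(C)cc3)C(=O)C[C@]2(c2ccccc2)O1`: 4300 nM

In a functional assay on HCT-116 cells (Homo sapiens) for cytotoxicity, read by sulforhodamine B assay, with a stated time of 48 h (a higher number here means a weaker inhibitor, a lower number a stronger inhibitor), compound 2 gives the lowest of the two numbers; compound 1 gives a number that is higher, beyond the scatter. Compound 3 `CO[C@@H]1CC=C2N(c3ccccn3)C(=O)C[C@]2(c2ccccc2)O1` carries the change (pyridin-2-yl in place of 4-methylphenyl on an amide-type nitrogen in a ring). Within the data shown here, no step of this kind has been measured here, so the direction is open; a step of modest size is expected, if any, and it is estimated as a 1.4-fold higher number from compound 2 to compound 3 (0.14 log units; within the scatter). Compound 3 is therefore expected to give about 6000 nM in this assay, within a range from 2000 nM to 20000 nM.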

Compound 3, half-maximal inhibitory concentration: 7300 nM
Compound 3: middle estimate off by 1.2-fold (0.09 log units), on the low side; low and high end bracket the measured number.
By their numbers in this assay, from the lowest: compounds 2, 3 and 1 (each within the scatter of the next, the first and the last beyond it).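

The first step measured at this amide-type nitrogen, pyridin-2-yl in place of 4-methylphenyl, reads a 1.7-fold higher number from compound 2 to compound 3 (0.23 log units; within the scatter) in this assay. This position therefore accepts an aromatic ring with a hetero atom and a hydrogen-bond acceptor, with the two compounds remaining within the scatter of each other. Nothing available here offers an explanation for this step.

Still open, as far as these compounds go, is whether a carboxylic acid, an aliphatic amine or a longer alkyl chain on this nitrogen would move the number beyond the scatter.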